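Cyclohexylmethyl amide within a cytotoxicity series

This account rests on a few compounds, and the source may have more. Where it says the series, first, only, none or still open, it means among the compounds named here.

Compound 1, `O=C(Nc1ccc(OC(F)F)cc1)c1cccc(/C=C2\CC(=O)N(c3ccccc3)C2=O)c1`: in an ADME assay on HCT-116 cells (Homo sapiens) for cytotoxicity, read by MTT assay, with a stated time of 72 h (a lower number here means a stronger inhibitor, a higher number a weaker inhibitor), compound 1 gives > 100000 nM, a limit of the assay.
Compound 2, `COc1ccc(NC(=O)c2cccc(/C=C3\CC(=O)N(c4ccccc4)C3=O)c2)c(C)c1`: in this assay compound 2 gives > 100000 nM, again a limit.
Compound 3, `COc1ccc(NC(=O)c2cccc(/C=C3\CC(=O)N(c4ccccc4)C3=O)c2)cc1`: in this assay compound 3 gives > 100000 nM, also a limit.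

Compound 3 therefore stands at the limit, as all three measured values sit at the limit of > 100000 nM in this assay, at which 3 of the 3 values shown sit. Among the measured compounds shown here, the steps a step that the two limits leave unreadable from compound 1 to compound 2, a step that the two limits leave unreadable from compound 1 to compound 3 and a step that the two limits leave unreadable from compound 2 to compound 3 are all unreadable, since every value is a limit; the series so far gives no readable step at all on this amide-type nitrogen. Compound 4, `O=C(NCC1CCCCC1)c1cccc(/C=C2\CC(=O)N(c3ccccc3)C2=O)c1`, differs from compound 3 by cyclohexylmethyl in place of 4-methoxyphenyl on an amide-type nitrogen. For the measured compounds named here, no measured step bears readably on this change, so no step beyond the scatter can be expected from it; the estimate for compound 4 in this assay is 150000 nM, within 40000 nM to 600000 nM, most probably reported as a limit again. The expected step is a step that the limit leaves unreadable from compound 3 to compound 4.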

Compound 4, half-maximal inhibitory concentration: > 100000 nM
Compound 4: a limit, no number (the forecaster's own chance of this, stated with the estimate: 85%); the middle value is on the limit's open side.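

In this assay compound 4 stands at a limit, as do compound 1, compound 2 and compound 3, so no step among these compounds can be read. Going by these compounds, whether any group on this amide-type nitrogen of the shared core gives a number in this assay stays open.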